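Steryl-sulfatase series: aryl swap at the benzylic amine

The compounds below may be only part of what the source reports. "The series", "measured", "known", "first", "only" and "open" are said of these compounds alone.

Within the data shown here, compound 2 `CCN(Cc1ccncc1)c1cccc(C(=O)N2CCc3ccc(OS(N)(=O)=O)cc3C2)c1` is the weaker of the two measured members. In an assay on HEK293 cells for inhibition of Steryl-sulfatase (Homo sapiens), tested at 1 uM (a lower number here means a weaker effect, a higher number a stronger effect of the compound at the concentration tested), compound 2 gives 52.8%, whereas compound 1 `CCN(Cc1ccccc1)c1cccc(C(=O)N2CCc3ccc(OS(N)(=O)=O)cc3C2)c1` gives 69%, the higher of the two numbers. Among the measured compounds shown here, the only measured step, a number 16.2 percentage points lower from compound 1 to compound 2 (beyond the scatter), separates these two compounds and is the sole guide for the next change.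

Compound 3 `CCN(Cc1ccc(F)cc1)c1cccc(C(=O)N2CCc3ccc(OS(N)(=O)=O)cc3C2)c1` is not yet measured. It differs from compound 2 by 4-fluorophenyl in place of pyridin-4-yl on a saturated chain carbon bound to a nitrogen on an aromatic ring. Compound 3 thus returns to a six-membered aromatic ring of carbon only, as in compound 1, with a fluorine added. The measured step that bears on this is a number 16.2 percentage points lower from compound 1 to compound 2 (beyond the scatter), which accompanied the move from a carbon-only ring to pyridin-4-yl; undoing that move is expected to give a step of comparable size in the opposite direction, because compound 1 stands at 69%. For the measured compounds named here, the fluorine has no precedent, so the expectation is set slightly under the level of compound 1. Compound 3 is expected to give 66% in this assay, with a range from 52% to 78%. The expected step, a number 13.2 percentage points higher from compound 2 to compound 3 (beyond the scatter), would lie beyond the scatter.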

Compound 3, a percentage reported as inhibition, at one concentration (the size of the read-out at that concentration, not a potency): 66.5%
Compound 3: middle estimate off by 0.5 percentage points, on the low side, and the stated range covers the measured number.
By their numbers in this assay, from the lowest: compound 2; then compounds 3 and 1 (each within the scatter of the next).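

In this assay, the pyridin-4-yl ring on the saturated chain carbon bound to a nitrogen on an aromatic ring now separates from a carbon-only ring in two pairs: a number 13.7 percentage points higher from compound 2 to compound 3 (beyond the scatter) joins the earlier a number 16.2 percentage points lower from compound 1 to compound 2 (beyond the scatter), so the lower number of compound 2 no longer rests on a single comparison. Fluoro in place of hydrogen on an aromatic carbon gives a number 2.5 percentage points lower from compound 1 to compound 3 (within the scatter), so at this single concentration the read-out does not separate 4-fluorophenyl from the unsubstituted phenyl of compound 1. The data on hand offer no explanation for either step.

Open is whether the ring nitrogen is tied to pyridin-4-yl alone, since pyridin-3-yl and pyridin-2-yl do not appear among these compounds, and whether chloro, methoxy or trifluoromethyl in the place of the fluorine would also stay within the scatter of compound 1. Also open, going by these compounds, are the ethyl group on the same nitrogen, where methyl or a longer chain could be read against these three compounds, and the effect of all three at other concentrations, as the read-out was taken at one concentration only.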